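The source may report more compounds than this note shows. Statements on the series, on what has been measured and on what is new or still open speak of the compounds shown alone.

Working notes on the series. Compound 1 `Cc1ccc(OCC(=O)N(Cc2cccs2)c2ccccn2)cc1` gives 200 nM in an assay on HEK293 cells for agonist activity at transient receptor potential cation channel subfamily M member 8 (Homo sapiens), read by fluorescence and calcium flux, with a stated time of 15 min; a higher number here means that more compound is needed for the effect, a lower number that less compound is needed. Compound 2 `CCC(C)N(Cc1cccs1)C(=O)COc1ccc(C)cc1` gives 2000 nM in this assay, and compound 3 `Cc1ccc(OCC(=O)N(Cc2cccs2)c2nccn2C)cc1` gives 1790 nM in this assay. That places compound 3 second highest of the three numbers, close to compound 2 and well apart from compound 1. The steps of a 10-fold higher number from compound 1 to compound 2 (1.00 log units; beyond the scatter) and a 9.0-fold higher number from compound 1 to compound 3 (0.95 log units; beyond the scatter) show that either replacement of pyridin-2-yl on the amide-type nitrogen moves the number upward by a comparable amount, while a 1.1-fold lower number from compound 2 to compound 3 (0.05 log units; within the scatter) lies within the scatter.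

Compound 4 `Cc1ccc(OCC(=O)N(Cc2cccs2)c2c(C)n[nH]c2C)cc1` differs from compound 3 by 3,5-dimethyl-1H-pyrazol-4-yl in place of 1-methyl-1H-imidazol-2-yl on an amide-type nitrogen. Within the data shown here, no measured step exchanges one five-membered ring for another at this position; the measured steps only show that a five-membered aromatic ring with 2 hetero atoms and a sec-butyl chain land at a similar number in this assay. Compound 4 is therefore expected to stay near compound 3, with a 1.1-fold higher number from compound 3 to compound 4 (0.05 log units; within the scatter) expected to fall within the scatter. The estimate for compound 4 in this assay is 2000 nM, between 800 nM and 6000 nM.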

Compound 4, half-maximal effective concentration: 0.3 nM
Compound 4: the middle estimate sits 6700-fold (3.82 log units) above what was measured; the measured number lies below the stated range.
By their numbers in this assay, from the lowest: compound 4; then compound 1; then compounds 3 and 2 (each within the scatter of the next).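

At this place on the amide-type nitrogen, two groups that both count as one five-membered aromatic ring with 2 hetero atoms are far from equivalent: in this assay the exchange gives a 6000-fold lower number from compound 3 to compound 4 (3.78 log units; beyond the scatter) and marks the ring itself as decisive. The other two comparisons, a 6700-fold lower number from compound 2 to compound 4 (3.82 log units; beyond the scatter) and a 670-fold lower number from compound 1 to compound 4 (2.82 log units; beyond the scatter) show that the earlier spread among sec-butyl, pyridin-2-yl and 1-methyl-1H-imidazol-2-yl covered only a small part of the range open at this position. Nothing available here explains the step.

Still open, as far as these compounds go, is how far the two methyl groups and the ring hydrogen on nitrogen each contribute. The compounds shown do not separate them, and 1H-pyrazol-4-yl without methyl groups or 1,3,5-trimethyl-1H-pyrazol-4-yl would address that question.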